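Swapping Methyl for Nitro on the Aromatic Ring

The source may hold more compounds than are shown below. What is called first, only, known or untested is meant among the compounds shown, and "the series" means these compounds.

Compound 1, `CC/C=C\COC1(c2ccc(Cl)cc2)SC=C(C)n2c1noc2=O`, gives 55000 nM in a functional assay on A2780 cells (Homo sapiens) for antiproliferative activity, read by MTT assay, with a stated time of 3 days; a lower number here means a stronger inhibitor, a higher number a weaker inhibitor. Compound 2, `CC1=CSC(O)(c2ccc(C)cc2)c2noc(=O)n21`, reaches only > 100000 nM in this assay, which is a limit of the assay and not a number. Compound 3, `COC1(c2ccc(Cl)cc2)SC=C(C)n2c1noc2=O`, gives 166000 nM.

Compound 2 therefore stands at the limit of > 100000 nM in this assay, at which 1 of the 3 values shown sits. Among the measured compounds shown here, the single measured step, a 3.0-fold higher number from compound 1 to compound 3 (0.48 log units; beyond the scatter), concerns the chain on the ether oxygen and says nothing about a group on the aromatic ring. Compound 4, `CC1=CSC(O)(c2ccc([N+](=O)[O-])cc2)c2noc(=O)n21`, differs from compound 2 by nitro in place of methyl on an aromatic carbon. For the measured compounds named here, with no measured step bearing on this change, no shift beyond the scatter is expected in this assay, in either direction. Compound 4 is expected to give about 120000 nM, between 40000 nM and 350000 nM, quite possibly again only a limit. The estimated step is a step that the limit leaves unreadable from compound 2 to compound 4.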

Compound 4, half-maximal inhibitory concentration: > 100000 nM
Compound 4: only a limit was reported (the forecaster's own chance of this, stated with the estimate: 60%); the middle value lies beyond the limit too.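

Among the compounds shown here, compound 2 and compound 4 each give only a limit of the assay, not a number, so no step between them can be read. As far as these compounds go, whether nitro in place of methyl changes the result at all in this assay remains open.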